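Aryl-on-sulfur variation in a diaminoquinoxaline-type series: compound 3

The source may hold more compounds than are shown below. What is called first, only, known or untested is meant among the compounds shown, and "the series" means these compounds.

Measured compounds:
Compound 1, `COc1ccc(Sc2nc3cc(N)cc(N)c3nc2-c2ccccc2)cc1`, in a functional assay on TK-10 cells (Homo sapiens) for inhibition, read by sulforhodamine B assay, with a stated time of 48 h (a higher number here means that more compound is tolerated, a lower number that less compound is tolerated), gives 72400 nM.
Compound 2, `Nc1cc(N)c2nc(-c3ccccc3)c(Sc3ccc(Cl)c(Cl)c3)nc2c1`, in this assay gives 53700 nM.

Among the measured compounds shown here, compound 2 holds the lowest of the two numbers measured so far, with compound 1 nearest; the single measured step, a 1.3-fold lower number from compound 1 to compound 2 (0.13 log units; within the scatter), lies within the scatter, so the two numbers are not separated by this assay. The next compound, compound 3, `Nc1cc(N)c2nc(-c3ccccc3)c(Sc3ccc(F)cc3)nc2c1`, differs from compound 2 in one place: 4-fluorophenyl in place of 3,4-dichlorophenyl on a sulfur. For the measured compounds named here, the only measured step that bears on this change is the aryl exchange on the same sulfur from compound 1 to compound 2, and it stayed within the scatter. Going by the values given here, no other step in the set speaks to this position. The expectation for compound 3 is therefore no step beyond the scatter, a 1.0-fold higher number from compound 2 to compound 3 (0.01 log units; within the scatter), in this assay. Compound 3 is thus estimated at 55000 nM, with a range from 25000 nM to 120000 nM.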

Compound 3, concentration lethal to 50% of the cells: < 100000 nM
Compound 3: a limit, no number; the forecaster's own chance of this, stated with the estimate: 10%; the middle value is on the limit's open side.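

In this assay compound 3 gives < 100000 nM, which is a limit and not a number. Among the compounds shown here, no step from compound 1 or compound 2 to compound 3 can be read. On these data alone, whether 4-fluorophenyl on the sulfur separates from 4-methoxyphenyl or 3,4-dichlorophenyl remains open.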